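Methoxy gives way to (oxetan-3-yl)oxy on compound 3

The source may report more compounds than this note shows. Statements on the series, on what has been measured and on what is new or still open speak of the compounds shown alone.

In a functional assay on HeLa cells (Homo sapiens) for antiproliferative activity, read by MTT assay, with a stated time of 48 h (on this read-out lower numbers stand for stronger inhibition and higher numbers for weaker inhibition), compound 1 (`COc1ccc(/C=C/C=C\c2cc(OC)c(OC)c(OC)c2)cc1O`) stands at 62 nM and compound 2 (`CCOc1cc(-c2ccc3cc[nH]c3c2)cn2c(-c3cc(OC)c(OC)c(OC)c3)nnc12`) at 272 nM while compound 3 (`COc1cc(-c2nnc3c(OC)cc(-c4ccc5[nH]ccc5c4)cn23)cc(OC)c1OC`) gives 85 nM as its value, within the scatter of compound 1 and clearly lower than compound 2. Compound 4 (`COc1cc(-c2nnc3c(OC4COC4)cc(-c4ccc5[nH]ccc5c4)cn23)cc(OC)c1OC`) has oxetan-3-yl in place of the methyl of compound 3 on an oxygen on an aromatic ring (oxetan-3-yl in place of methyl on an oxygen on an aromatic ring). Going by the values given here, no two measured compounds differ in one place only, so the data give no direct guide to this change. A modest loss is expected in this assay with the estimated 2.0-fold higher number from compound 3 to compound 4 (0.30 log units; within the scatter) pointing towards weaker inhibition, though it may stay close to the scatter. Compound 4 is estimated at 170 nM with an expected range of 60 nM to 500 nM around that figure.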

Compound 4, half-maximal inhibitory concentration: 2780 nM
Compound 4: middle estimate off by 16-fold (1.21 log units), on the low side, outside the stated range (above it).
By their numbers in this assay, from the lowest: compounds 1 and 3 (each within the scatter of the next); then compound 2; then compound 4.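

In this assay, going by these compounds alone, the change from methoxy to (oxetan-3-yl)oxy gives a 33-fold higher number from compound 3 to compound 4 (1.51 log units; beyond the scatter), the first single-place step. It shows that the group on this oxygen strongly affects inhibition, and that this larger group with its four-membered ring is poorly tolerated here. Nothing available explains the size of this loss.

The compounds shown leave open whether the loss belongs to the ring as a whole or to its oxygen, which a cyclobutyl group on the same oxygen would help to separate. They also leave open how an open chain carrying an amine would fare at this place.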